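The source may report more compounds than this note shows. Statements on the series, on what has been measured and on what is new or still open speak of the compounds shown alone.

Working notes on the diaminoquinoxaline set, read in a functional assay on KM12 cells (Homo sapiens) for inhibition, read by sulforhodamine B assay, with a stated time of 48 h; on this read-out higher numbers stand for weaker inhibition of growth and lower numbers for stronger inhibition of growth.

Compound 1, `Nc1cc(N)c2nc(-c3ccccc3)c(Oc3ccc(Cl)c(Cl)c3)nc2c1`, gives 39800 nM. Compound 2, `COc1cc(CNc2nc3cc(N)cc(N)c3nc2-c2ccccc2)cc(OC)c1OC`, gives 10200 nM. Of these two numbers compound 1 is the higher, and the gap between them lies beyond the usual scatter of repeated runs. Compound 3, `CCOC(=O)[C@H](CCC(=O)O)NC(=O)c1ccc(Oc2nc3cc(N)cc(N)c3nc2-c2ccccc2)cc1`, returns only a limit in this assay, < 100000 nM, so it carries no number of its own; see (the limit of < 100000 nM in this assay, at which 1 of the 3 values shown sits). Among the measured compounds shown here, no two of the measured compounds differ in a single place, so no measured step within this assay can be drawn on for the change below.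

Compound 4, `Nc1cc(N)c2nc(-c3ccccc3)c(Oc3ccc(F)cc3)nc2c1`, has not yet been run. It differs from compound 1 in one place: 4-fluorophenyl in place of 3,4-dichlorophenyl on an oxygen on an aromatic ring. For the measured compounds named here, the two measured numbers give no single-point precedent for swapping substituents on this aromatic ether oxygen, so the expectation rests only on the weak starting point of compound 1 at 39800 nM.

The step from compound 1 to compound 4 is expected to be small, a 1.5-fold higher number from compound 1 to compound 4 (0.18 log units; within the scatter), most likely a somewhat higher number, but plausibly none beyond the scatter. For compound 4 the estimate is 60000 nM, in a range from 18000 nM to 200000 nM, with a real chance that this assay returns only a limit for compound 4.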

Compound 4, concentration for total growth inhibition: 40700 nM
The estimate for compound 4 lay 1.5-fold (0.17 log units) above the measured number, within the range that was stated.
By their numbers in this assay, from the lowest: compound 2; then compounds 1 and 4 (each within the scatter of the next).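

In this assay, among the compounds shown here, the exchange of 3,4-dichlorophenyl for 4-fluorophenyl on the oxygen on an aromatic ring gives the first step in the set that can be read, a 1.0-fold higher number from compound 1 to compound 4 (0.01 log units; within the scatter), and it shows no separation between the two rings. This change removes one heavy atom and replaces both chlorine atoms with a single fluorine, yet compound 1 and compound 4 cannot be told apart on this read-out, so neither ring can be ranked over the other at this place. No measurement shown bears on why the two rings read alike.

From the compounds shown here alone, whether any change on this oxygen can move the number remains open, since only these two halogen-bearing phenyl groups can be compared there, and a phenyl ring carrying an amine or a carboxylic acid, or a longer chain between the oxygen and the ring, would test this more widely. Steps from compound 2 and compound 3 to the other compounds cannot be read, as each differs from them in more than one place.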